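Swapping 3-Hydroxyphenyl for 4-Hydroxyphenyl on a Second Core

This account rests on a few compounds, and the source may have more. Where it says the series, first, only, none or still open, it means among the compounds named here.

Compound 1, `Oc1cccc(-c2cc(-c3ccccc3)cc(-c3cccs3)n2)c1`: 10900 nM
Compound 2, `Oc1ccc(-c2cc(-c3ccccc3)cc(-c3cccs3)n2)cc1`: 12500 nM
Compound 3, `Oc1cccc(-c2cc(-c3ccccc3)nc(-c3ccco3)c2)c1`: 13900 nM

These three compounds were tested in a functional assay on HCT-15 cells (Homo sapiens) for cytotoxicity, read by ELISA, with a stated time of 2 days; a lower number here means a stronger inhibitor, a higher number a weaker inhibitor. Compound 1 and compound 2 share one core and differ by 4-hydroxyphenyl in place of 3-hydroxyphenyl on an aromatic carbon; the step was a 1.1-fold higher number from compound 1 to compound 2 (0.06 log units; within the scatter). Compound 3 sits on a second core; how that core differs from the core of compound 1 is not broken down here. In this assay compound 3 gives a number within the scatter of both compound 1 and compound 2.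

Compound 4, `Oc1ccc(-c2cc(-c3ccccc3)nc(-c3ccco3)c2)cc1`, has not yet been measured. It differs from compound 3 by 4-hydroxyphenyl in place of 3-hydroxyphenyl on an aromatic carbon, the same kind of change as before, though the place is now opposite the ring nitrogen rather than next to it. Because the earlier step was a 1.1-fold higher number from compound 1 to compound 2 (0.06 log units; within the scatter), a step of about a 1.1-fold higher number from compound 3 to compound 4 (0.03 log units; within the scatter) is expected here. Compound 4 is therefore estimated at 15000 nM, most likely between 7500 nM and 30000 nM.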

Compound 4, half-maximal inhibitory concentration: 5100 nM
Compound 4: the middle estimate sits 2.9-fold (0.47 log units) above what was measured, and the stated range ends above it.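

On the second core, 4-hydroxyphenyl in place of 3-hydroxyphenyl gave a 2.7-fold lower number from compound 3 to compound 4 (0.44 log units; beyond the scatter) in this assay, so the change did not carry over unchanged from the first core: the same change on two cores in this assay, a 1.1-fold higher number (0.06 log units; within the scatter) from compound 1 to compound 2 and a 2.7-fold lower number (0.44 log units; beyond the scatter) from compound 3 to compound 4, 3.1-fold (0.49 log units) apart, beyond the scatter of two such steps

In these two pairs, then, the outcome of the same swap differed with the core. Two pairs do not show which difference between the cores is responsible, and they do not establish a rule for the wider series.

The compounds shown carry only a hydroxyl group on this phenyl ring. Going by these compounds, whether an amine or a carboxylic acid in its place would also give different results on the two cores remains open.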